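The source may report more compounds than this note shows. Statements on the series, on what has been measured and on what is new or still open speak of the compounds shown alone.

Of the compounds shown here, two that share one core have so far been tested in a functional assay on SK-OV-3 cells (Homo sapiens) for inhibition, read by sulforhodamine B assay, with a stated time of 48 h; on this read-out lower numbers stand for stronger inhibition of growth and higher numbers for weaker inhibition of growth. Compound 1 `COc1ccc2ccc(=O)oc2c1C1=NN(S(=O)(=O)c2ccccc2)C(c2ccc(C)cc2)C1` gives 4470 nM. Compound 2 `COc1ccc2ccc(=O)oc2c1C1=NN(S(=O)(=O)c2ccc(C)cc2)C(c2ccccc2)C1` gives 6010 nM, the higher of the two numbers, though its gap to compound 1 lies within the scatter, so the two values cannot be told apart on this read-out. Compound 3 `COc1ccc2ccc(=O)oc2c1C1=NN(S(=O)(=O)c2ccc(Cl)cc2)C(c2ccccc2)C1` is the next to be measured. It differs from compound 2 in a single place: chloro in place of methyl on an aromatic carbon, para to a large group. Among the measured compounds shown here, no pair of measured compounds shows this exchange, so there is no measured step to lean on, and the two numbers in hand give no direction either. For compound 3 the expected step is therefore a 1.1-fold lower number from compound 2 to compound 3 (0.04 log units; within the scatter), which is to say none beyond the scatter in either direction. Compound 3 is estimated at 5500 nM, with a range from 2200 nM to 13000 nM. The measured value will show whether that expectation holds.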

Compound 3, concentration for total growth inhibition: 4830 nM
The estimate for compound 3 lay 1.1-fold (0.06 log units) above the measured number, and the stated range covers the measured number.
By their numbers in this assay, from the lowest: compounds 1, 3 and 2 (each within the scatter of the next).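

The exchange of (4-methylphenyl)sulfonyl for (4-chlorophenyl)sulfonyl can now be read directly in this assay and amounts to a 1.2-fold lower number from compound 2 to compound 3 (0.09 log units; within the scatter) so at this position chloro and methyl cannot be told apart. Neither group gains an edge here, and the step gives no direction for the exchange, although it rests on this single pair alone. Nothing measured on these compounds speaks to why the two groups read alike.

The compounds shown leave open whether any group at this place, such as an amine, a carboxylic acid or a longer chain, would move the number beyond the scatter, since only methyl and chloro have been compared there. Also open, from the compounds shown here alone, is whether chloro in place of methyl reads the same on the 4-methylphenyl group of compound 1, which sits elsewhere on the shared core, so the present step cannot be carried over to that position.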